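The source may hold more compounds than are shown below. What is called first, only, known or untested is meant among the compounds shown, and "the series" means these compounds.

Measured compounds and their values:
Compound 1, `COc1ccc(C=C(C(=O)/C=C/c2cccc(OC)c2OC)C(=O)/C=C/c2cccc(OC)c2OC)cc1OC`, gives 200 nM.
Compound 2, `COc1ccc(C=C(C(=O)/C=C/c2cccc(OC)c2OC)C(=O)/C=C/c2cccc(OC)c2OC)cc1O`, gives 270 nM.
Compound 3, `COc1ccc(OC)c(/C=C/C(=O)C(=Cc2ccc(O)c(OC)c2)C(=O)/C=C/c2cc(OC)ccc2OC)c1`, gives 340 nM.

All three were tested in a functional assay on HepG2 cells (Homo sapiens) for antiproliferative activity, read by sulforhodamine B assay, with a stated time of 48 h; a higher number here means a weaker inhibitor, a lower number a stronger inhibitor. Compound 2 and compound 1 share a core and differ in one place: methyl in place of hydrogen on an oxygen on an aromatic ring. That step, a 1.4-fold lower number from compound 2 to compound 1 (0.13 log units; within the scatter), is within the scatter. Compound 3 has the same atoms as compound 2 joined differently; the difference between the two cores is not broken down here. Its value and those of compound 1 and compound 2 lie within the scatter of one another, so no order among them is claimed.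

Compound 4, `COc1ccc(OC)c(/C=C/C(=O)C(=Cc2ccc(OC)c(OC)c2)C(=O)/C=C/c2cc(OC)ccc2OC)c1`, has not yet been measured. It stands to compound 3 as compound 1 stands to compound 2: methyl in place of hydrogen on an oxygen on an aromatic ring. The place is the same as before, though the surrounding reading one bond further out differs, so this is the same change made on the other core. Compound 4 is expected to give 260 nM, with a range from 130 nM to 520 nM. The expected step, a 1.3-fold lower number from compound 3 to compound 4 (0.12 log units; within the scatter), rests on compound 2 and compound 1, because a 1.4-fold lower number from compound 2 to compound 1 (0.13 log units; within the scatter) stayed within the scatter.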

Compound 4, half-maximal inhibitory concentration: 260 nM
Compound 4: the middle estimate sits on the measured number at the digits printed; the range from low to high includes it.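

In this assay the change from hydroxy to 3,4-dimethoxyphenyl's methoxy, that is from 4-hydroxy-3-methoxyphenyl to 3,4-dimethoxyphenyl, gives a 1.3-fold lower number from compound 3 to compound 4 (0.12 log units; within the scatter) and sits close to the same change on the other core: the same change on two cores in this assay, a 1.4-fold lower number (0.13 log units; within the scatter) from compound 2 to compound 1 and a 1.3-fold lower number (0.12 log units; within the scatter) from compound 3 to compound 4, 1.0-fold (0.01 log units) apart, within the scatter of two such steps. Across these two cores, then, the change carried over with no difference that can be told apart, and a step read on one core matched the step on the other. Both steps lie within the scatter, however, so their agreement does not show that the methyl does anything measurable on either core, and it says nothing about cores beyond these two.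

The compounds shown carry only hydrogen or methyl on this oxygen, which leaves open what a longer chain there, such as ethyl or propyl, would give. They also leave open what an amine or a carboxylic acid in place of the hydroxy would give in this assay on either core.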